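The source may hold more compounds than are shown below. What is called first, only, known or untested is meant among the compounds shown, and "the series" means these compounds.

Compounds in this set share one core. Compound 1 `CN(C)C(=O)c1cc2cnc(Nc3ccc(S(=O)(=O)NCCCN=C=S)cc3)nc2n1C1CCCC1` and compound 2 `CN(C)C(=O)c1cc2cnc(Nc3ccc(S(=O)(=O)NCCCCCN=C=S)cc3)nc2n1C1CCCC1` carry a sulfonamide link, while compound 3 `CN(C)C(=O)c1cc2cnc(Nc3ccc(C(=O)NCCCN=C=S)cc3)nc2n1C1CCCC1` carries an amide link in its place. In a functional assay on NCI-H1299 cells (Homo sapiens) for inhibition, read by CCK-8 assay, with a stated time of 72 h, tested at 1 uM (a higher number here means a stronger effect of the compound at the concentration tested, a lower number a weaker effect), compound 1 gives 41.3%, compound 2 gives 52.1% and compound 3 gives 65.1%. Compound 3 therefore stands highest of the three numbers: the step of a number 23.8 percentage points higher from compound 1 to compound 3 (beyond the scatter) and the step of a number 13 percentage points higher from compound 2 to compound 3 (beyond the scatter) both lie beyond the scatter.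

Compound 4 `CN(C)C(=O)c1cc2cnc(Nc3ccc(C(=O)NCCCCCCCN=C=S)cc3)nc2n1C1CCCC1` has not yet been measured. It differs from compound 3 by a group of 7 heavy atoms (5 carbon, 1 nitrogen, 1 sulfur; no ring) in place of a group of 3 heavy atoms (1 carbon, 1 nitrogen, 1 sulfur; no ring), on a saturated chain carbon, three bonds along the chain from an amide-type nitrogen. Among the compounds with values here, the one measured step that bears on this kind of change is the one on the sulfonamide side, a number 10.8 percentage points higher from compound 1 to compound 2 (beyond the scatter), which was modest and upward. Within the data shown here, the change from compound 3 to compound 4 is of the same kind but carried further along the chain, and no measured compound shows whether such extension keeps helping at that length. The expected step is therefore a modest rise, a number 5.9 percentage points higher from compound 3 to compound 4 (within the scatter), with a real chance that it stays within the scatter. Compound 4 is estimated at 71% in this assay, with a range from 55% to 85%.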

Compound 4, a percentage reported as inhibition, at one concentration (the size of the read-out at that concentration, not a potency): 75.7%
The estimate for compound 4 lay 4.7 percentage points below the measured number, within the range that was stated.
By their numbers in this assay, from the lowest: compound 1; then compound 2; then compound 3; then compound 4.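

On the amide side, lengthening now has a measured step of its own: in this assay, the group of 7 heavy atoms in place of the group of 3 heavy atoms, three bonds along the chain from an amide-type nitrogen, gives a number 10.6 percentage points higher from compound 3 to compound 4 (beyond the scatter), and this step lies beyond the scatter. Within the data shown here, until now the only lengthening step stood on the sulfonamide side, a number 10.8 percentage points higher from compound 1 to compound 2 (beyond the scatter), so a longer chain now goes with a higher number with either link, in these two pairs and with no pair going against them. Nothing measured alongside these percentages accounts for the rise at this position.

The compounds shown leave open whether a still longer chain keeps raising the number or whether the rise stops at some length, and how a sulfonamide link would read with the group of 7 heavy atoms. They also leave open what the end of the chain contributes, since every compound here keeps the isothiocyanate there and none carries an amine or a carboxylic acid in its place.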